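Swapping Chloro for Diethylcarbamoyl: An Expected Potency Shift

The source may hold more compounds than are shown below. What is called first, only, known or untested is meant among the compounds shown, and "the series" means these compounds.

Of the compounds shown here, three sharing one core have been tested in an assay on isolated protein for inhibition of Dihydrofolate reductase (Homo sapiens), read by spectrophotometry, using NADPH, with a stated time of 10 min; a lower number here means a stronger inhibitor, a higher number a weaker inhibitor. Compound 1 `CCOc1ccc(Cl)cc1-c1cc2nc(N)nc(N)c2cc1C` gives 11.1 nM, the lowest of the three numbers. Compound 3 `CCOc1ccc2[nH]ccc2c1-c1cc2nc(N)nc(N)c2cc1C` gives 245 nM, and compound 2 `Nc1ccc(-c2ccc3c(N)nc(N)nc3c2)cc1` gives 702 nM; both lie beyond the usual scatter from compound 1, which is therefore the strongest inhibitor measured so far. Compound 4 `CCOc1ccc(C(=O)N(CC)CC)cc1-c1cc2nc(N)nc(N)c2cc1C` has not yet been tested in this assay. It differs from compound 1 in a single place: diethylcarbamoyl in place of chloro on an aromatic carbon. Among the compounds with values here, no measured pair shows this exact change, so the expectation rests on compound 1 alone. The expected step is a 7.2-fold higher number from compound 1 to compound 4 (0.86 log units; beyond the scatter), toward a weaker inhibitor. Compound 4 is estimated at 80 nM, with a range from 20 nM to 400 nM.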

Compound 4, inhibition constant: 34 nM
Compound 4: middle estimate off by 2.4-fold (0.37 log units), on the high side, and the stated range covers the measured number.
By their numbers in this assay, from the lowest: compound 1; then compound 4; then compound 3; then compound 2.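

In this assay, the aromatic carbon para to an ethoxy group accepts diethylcarbamoyl in place of chloro at only a modest cost (a 3.1-fold higher number from compound 1 to compound 4 (0.49 log units; beyond the scatter)). Within the data shown here, this is the first measured step at this position, and it shows that a far larger group carrying a hydrogen-bond acceptor still leaves a strong inhibitor. Nothing available explains why the number rises.

Still open, as far as these compounds go, is how a carboxylic acid, an amine or a primary amide would behave at this carbon. Also open, from the compounds shown here alone, is whether shorter or longer chains on the amide nitrogen would move the number.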